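Replacing the chain amine with a diol in a flavone series

The compounds below may be only part of what the source reports. "The series", "measured", "known", "first", "only" and "open" are said of these compounds alone.

Compound 1 `COc1cc(OC)c2c(=O)cc(-c3ccc(OC4CCNCC4)cc3)oc2c1` gives 21% in a functional assay (Homo sapiens) for antiproliferative activity, read by resazurin assay, with a stated time of 48 h, tested at 10 uM; a lower number here means a weaker effect, a higher number a stronger effect of the compound at the concentration tested.
Compound 2 `COc1cc(OC)c2c(=O)cc(-c3ccc(OCCCN)cc3)oc2c1` gives 39% in this assay.

Compound 2 stands highest of the two numbers; its nearest neighbour is compound 1, and the step of a number 18 percentage points higher from compound 1 to compound 2 (beyond the scatter) lies beyond the scatter. Compound 3 `COc1cc(OC)c2c(=O)cc(-c3ccc(OCC(O)CO)cc3)oc2c1` differs from compound 2 by 1,2-dihydroxyethyl in place of 2-aminoethyl on a saturated chain carbon bound to an oxygen on an aromatic ring. Going by the values given here, the only measured step swaps one amine for another and bears on this change only loosely, so the direction is uncertain. Compound 3 is expected to show 25% with a range of 5% to 50%. The step of a number 14 percentage points lower from compound 2 to compound 3 (beyond the scatter) is therefore estimated, most likely downward, but it may fall within the scatter.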

Compound 3, a percentage reported as inhibition, at one concentration (the size of the read-out at that concentration, not a potency): 11%
The estimate for compound 3 lay 14 percentage points above the measured number; the measured number falls inside the stated range.
By their numbers in this assay, from the lowest: compounds 3 and 1 (each within the scatter of the next); then compound 2.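

In this assay, exchanging 3-aminopropoxy for 2,3-dihydroxypropoxy gives a number 28 percentage points lower from compound 2 to compound 3 (beyond the scatter), so the higher number of compound 2 does not survive the loss of the chain amine, which the earlier comparison of two amines could not show. The diol chain and the piperidin-4-yl group are not separated, with a number 10 percentage points lower from compound 1 to compound 3 (within the scatter) as the printed step. No evidence is available to explain these steps. Still open, on these data alone, is whether the amine itself matters or any chain end would do, as a carboxylic acid, a dimethylamine or a longer aminoalkyl chain at this position might tell.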